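Removing the Amino Group from a Pyridylmethyl Imine Anticonvulsant

The source may hold more compounds than are shown below. What is called first, only, known or untested is meant among the compounds shown, and "the series" means these compounds.

Going by the values given here, compound 1 `C/C(=N\Cc1cccnc1)c1cccc(N)c1` gives the lowest of the two numbers so far recorded in a functional assay on the whole organism (strain Swiss albino) with Mus musculus as the target, in the maximal electroshock model, with a stated time of 4 h; a higher number here means that more compound is needed for the effect, a lower number that less compound is needed: compound 1 needs 30 mg/kg, while compound 2 `O=[N+]([O-])c1ccc(/C=N/Cc2cccnc2)cc1` needs 100 mg/kg, a higher number beyond the usual scatter. Compound 3 `C/C(=N\Cc1cccnc1)c1ccccc1` is not yet measured. Compound 3 differs from compound 1 by hydrogen in place of amino on an aromatic carbon. Among the compounds with values here, no step between measured compounds covers this change, so a modest upward step is expected in this assay, likely within or just beyond the scatter, as a 2.0-fold higher number from compound 1 to compound 3 (0.30 log units; within the scatter). Compound 3 is therefore estimated at 60 mg/kg, within a range from 30 mg/kg to 150 mg/kg.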

Compound 3, minimum effective dose: 30 mg/kg
Compound 3: the middle estimate sits 2.0-fold (0.30 log units) above what was measured, and the stated range covers the measured number.
By their numbers in this assay, from the lowest: compounds 1 and 3 (each within the scatter of the next); then compound 2.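

Hydrogen in place of amino on this aromatic carbon gives no change at the digits printed from compound 1 to compound 3 (within the scatter) in this assay. The amino group, with its hydrogen-bond donor and acceptor, is therefore not required at this place for the effect seen with the shared core. No measurement shown here bears on why this position tolerates the change.

Still open, from the compounds shown here alone, is whether other groups on this aromatic carbon, such as a methoxy group, a chlorine atom or a carboxylic acid, would give a number close to those of compound 1 and compound 3.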